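A Larger Group at the Same Crowded Aromatic Carbon

A few compounds are considered here, and "the series" means these few. Any claim that something is new, unique, unknown or untested is made for them only; others in the source may bear on it.

Compound 1 `Nc1ccc(-c2cc(=O)c3c(N)c(F)cc(F)c3o2)cc1F` gives 40 nM in a functional assay on MCF7 cells (Homo sapiens) for cytotoxicity, read by neutral red uptake, with a stated time of 3 days (on this read-out lower numbers stand for stronger inhibition and higher numbers for weaker inhibition), the lowest of the two numbers measured. Compound 2 `CCCCc1c(F)c(N)c2c(=O)cc(-c3ccc(N)c(F)c3)oc2c1F` gives 8800 nM in the same assay. Compound 3 `Nc1ccc(-c2cc(=O)c3c(N)c(F)c(O)c(F)c3o2)cc1F` reaches only the limit of the assay, > 10000 nM. Compound 4 `CN(C)CC(=O)OCc1c(F)c(N)c2c(=O)cc(-c3ccc(N)c(F)c3)oc2c1F` differs from compound 1 by ((((dimethylamino)methyl)carbonyl)oxy)methyl in place of hydrogen on an aromatic carbon. Among the compounds with values here, two measured steps bear on this change, each placing a group on that same aromatic carbon: a 220-fold higher number from compound 1 to compound 2 (2.34 log units; beyond the scatter) and an at least 250-fold higher number from compound 1 to compound 3 (2.39 log units; beyond the scatter). Both are large losses, so a large step toward a higher number is expected, a 150-fold higher number from compound 1 to compound 4 (2.18 log units; beyond the scatter). Compound 4 is estimated at 6000 nM, with a range from 800 nM to 30000 nM, and a fair chance that only the limit of > 10000 nM in this assay, at which 1 of the 3 values shown sits, is reported.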

Compound 4, half-maximal inhibitory concentration: 26 nM
Beside the measured number, compound 4's estimate is 230-fold (2.36 log units) above it, outside the stated range (below it).
By their numbers in this assay, from the lowest: compounds 4 and 1 (each within the scatter of the next); then compound 2. At a limit, above all of these: compound 3.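

At this aromatic carbon, ortho to two fluoro groups, this assay shows that a group need not bring a loss: ((((dimethylamino)methyl)carbonyl)oxy)methyl in place of hydrogen gives a 1.5-fold lower number from compound 1 to compound 4 (0.19 log units; within the scatter). The same carbon also carries a 340-fold lower number from compound 2 to compound 4 (2.53 log units; beyond the scatter) and an at least 380-fold lower number from compound 3 to compound 4 (2.58 log units; beyond the scatter), the latter a floor set by a limit. Nothing measured here says why this group differs from butyl and hydroxy.

From the compounds shown here alone, it remains open whether a dimethylaminomethyl group, without the ester, or a plain acetoxymethyl group would keep the number of compound 4.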